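The source may report more compounds than this note shows. Statements on the series, on what has been measured and on what is new or still open speak of the compounds shown alone.

Working notes on the series built on the shared core of compound 1 `O=C(NO)c1ccc(/C=C/c2ccnc(-c3cc(F)ccc3O)c2)cc1`, all read in a functional assay on HCT-116 cells (Homo sapiens) for antiproliferative activity, read by CellTiter-Glo, with a stated time of 72 h; on this read-out higher numbers stand for weaker inhibition and lower numbers for stronger inhibition. Compound 1 gives 2040 nM, the lowest of the two numbers shown. Compound 3 `O=C(NO)c1ccc(/C=C/c2ccncc2)cc1` gives 3910 nM in this assay, and the step of a 1.9-fold higher number from compound 1 to compound 3 (0.28 log units; within the scatter) keeps the two within the scatter. Compound 2 `O=C(NO)c1ccc(/C=C/c2ccnc(-c3ccc(F)cc3)c2)cc1` reaches only a limit, > 10000 nM in this assay, and the limit of > 10000 nM in this assay, at which 1 of the 3 values shown sits, is the boundary of this set. The step of an at least 4.9-fold higher number from compound 1 to compound 2 (0.69 log units; beyond the scatter) is beyond the scatter, as is an at least 2.5-fold lower number from compound 2 to compound 3 (0.40 log units; beyond the scatter).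

Compound 4 `O=C(NO)c1ccc(/C=C/c2ccnc(-c3ccsc3)c2)cc1` is not yet measured. The change from compound 1 is thiophen-3-yl in place of 5-fluoro-2-hydroxyphenyl on an aromatic carbon. For the measured compounds named here, two measured steps bear on it: an at least 4.9-fold higher number from compound 1 to compound 2 (0.69 log units; beyond the scatter), where a ring without the hydroxyl group stood in place of 5-fluoro-2-hydroxyphenyl, and a 1.9-fold higher number from compound 1 to compound 3 (0.28 log units; within the scatter), where the group was removed altogether. Thiophen-3-yl, like the 4-fluorophenyl of compound 2, carries no hydrogen-bond donor; given an at least 4.9-fold higher number from compound 1 to compound 2 (0.69 log units; beyond the scatter), a higher number in this assay than compound 1 is expected for compound 4, of modest size and possibly reaching the limit. Compound 4 is estimated at 5000 nM, between 2000 nM and 12000 nM. This estimate means a step of a 2.5-fold higher number from compound 1 to compound 4 (0.39 log units; beyond the scatter) is expected.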

Compound 4, half-maximal inhibitory concentration: 1910 nM
The estimate for compound 4 lay 2.6-fold (0.42 log units) above the measured number, and the stated range ends above it.
By their numbers in this assay, from the lowest: compounds 4, 1 and 3 (each within the scatter of the next, the first and the last beyond it). At a limit, above all of these: compound 2.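

The step of a 1.1-fold lower number from compound 1 to compound 4 (0.03 log units; within the scatter) shows that in this assay a hydroxyl group is not needed on the ring at this place next to the ring nitrogen: thiophen-3-yl, with 0 hydrogen-bond donors, reads level with 5-fluoro-2-hydroxyphenyl, so the missing donor alone cannot account for compound 2. An aromatic ring here can also bring a modest gain over hydrogen, a 2.0-fold lower number from compound 3 to compound 4 (0.31 log units; beyond the scatter), which the within-scatter step from compound 1 to compound 3 did not show. Two rings without a donor can also part clearly, an at least 5.2-fold lower number from compound 2 to compound 4 (0.71 log units; beyond the scatter), and compound 2 is a limit: the limit of > 10000 nM in this assay, at which 1 of the 4 values shown sits.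

The compounds shown leave open whether ring size, the sulfur or the fluorine separates compound 2 from compound 4, as those two rings differ in more than one respect. Plain phenyl, furan-3-yl or thiophen-2-yl at this place would bear on that question, and an aminophenyl would show whether another donor-bearing ring behaves like 5-fluoro-2-hydroxyphenyl.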